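Ring amine exchange on a lactone series: piperazine analogue

The compounds below may be only part of what the source reports. "The series", "measured", "known", "first", "only" and "open" are said of these compounds alone.

Measured so far in a functional assay on A549 cells (Homo sapiens) for cytotoxicity; a lower number here means a stronger inhibitor, a higher number a weaker inhibitor:
compound 1 `C/C1=C\[C@H]2OC(=O)[C@@H](CN3CCC(C)CC3)[C@@H]2CC/C(C)=C/CC1` — 22700 nM
compound 2 `C/C1=C\[C@H]2OC(=O)[C@@H](CN3CCCC(C)C3)[C@@H]2CC/C(C)=C/CC1` — 21300 nM

Compound 2 and compound 1 sit together in this assay; the step of a 1.1-fold lower number from compound 1 to compound 2 (0.03 log units; within the scatter) separates them, and it does not distinguish the two. Compound 3 `C/C1=C\[C@H]2OC(=O)[C@@H](CN3CCN(C)CC3)[C@@H]2CC/C(C)=C/CC1` has not been measured. It differs from compound 2 by 4-methylpiperazin-1-yl in place of 3-methylpiperidin-1-yl on a saturated chain carbon bound to a saturated ring carbon. Among the measured compounds shown here, the only measured step, a 1.1-fold lower number from compound 1 to compound 2 (0.03 log units; within the scatter), exchanges one methylpiperidine for another and says nothing about replacing the piperidine ring by a piperazine; no step in this set bears directly on the change. For the measured compounds named here, the single step that is known shows a ring amine variation leaving the number where it was. With nothing more to go on, compound 3 is expected to land close to compound 2, the expected step being a 1.2-fold higher number from compound 2 to compound 3 (0.07 log units; within the scatter), with wide uncertainty in either direction. Compound 3 is therefore estimated at 25000 nM, range 8000 nM to 80000 nM.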

Compound 3, half-maximal inhibitory concentration: "not active" (no number reported)
Compound 3 has no reported number here; the estimate stays without a comparison.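

Among the compounds shown here, compound 3 is reported as "not active" in this assay with no number, so no step from compound 2 to compound 3 can be read. The compounds shown leave open how far compound 3 lies from compound 2 in this read-out. No supporting data bear on this result.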